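Acetyl for ethoxy on the chain of compound 3

The source may hold more compounds than are shown below. What is called first, only, known or untested is meant among the compounds shown, and "the series" means these compounds.

Compound 1, `C=CCn1c(=O)c2[nH]cnc2n(CCC)c1=O`: in an assay on Cerebral cortex for binding affinity to adenosine receptor A1 (Cavia porcellus), read by radioligand binding (a lower number here means a stronger inhibitor, a higher number a weaker inhibitor), compound 1 gives 1700 nM.
Compound 2, `CCCn1c(=O)n(CCC#N)c(=O)c2[nH]cnc21`: in this assay compound 2 gives 15900 nM.
Compound 3, `CCCn1c(=O)n(CCOCC)c(=O)c2[nH]cnc21`: in this assay compound 3 gives 1900 nM.

Among these three, compound 3 stands second highest. Its nearest neighbour is compound 1, with a 1.1-fold higher number from compound 1 to compound 3 (0.05 log units; within the scatter), a gap within the scatter. Its furthest is compound 2, with an 8.4-fold lower number from compound 2 to compound 3 (0.92 log units; beyond the scatter), a gap beyond the scatter.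

Compound 4, `CCCn1c(=O)n(CCC(C)=O)c(=O)c2[nH]cnc21`, differs from compound 3 in one place: acetyl in place of ethoxy on a saturated chain carbon, two bonds along the chain from an aromatic nitrogen. Among the measured compounds shown here, the one measured step that bears on this position is the exchange of cyano for ethoxy on the same chain carbon, where the number fell with an 8.4-fold lower number from compound 2 to compound 3 (0.92 log units; beyond the scatter); the step of a 9.4-fold higher number from compound 1 to compound 2 (0.97 log units; beyond the scatter) shows the same cyano-bearing chain from the other side. For the measured compounds named here, no measured pair shows acetyl itself, so the expectation rests on acetyl sharing with cyano a multiple bond outside aromatic rings while keeping the single acceptor that ethoxy had.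

Compound 4 is therefore expected to give about 5000 nM in this assay, within a range from 1500 nM to 16000 nM. The step this estimate implies, a 2.6-fold higher number from compound 3 to compound 4 (0.42 log units; beyond the scatter), is expected to be modest and upward, but could fall within the scatter.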

Compound 4, inhibition constant: 11200 nM
Beside the measured number, compound 4's estimate is 2.2-fold (0.35 log units) below it; the range from low to high includes it.
By their numbers in this assay, from the lowest: compounds 1 and 3 (each within the scatter of the next); then compounds 4 and 2 (each within the scatter of the next).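

Ethoxy and acetyl enter this chain carbon with the same counts of heavy atoms and hydrogen-bond acceptors, yet the exchange gives a 5.9-fold higher number from compound 3 to compound 4 (0.77 log units; beyond the scatter) in this assay and so those counts alone do not set the number at this position. Acetyl and cyano cannot be told apart here, since a 1.4-fold lower number from compound 2 to compound 4 (0.15 log units; within the scatter) lies within the scatter and places the carbonyl chain of compound 4 with the nitrile chain of compound 2 rather than with the ether chain of compound 3. A double bond outside aromatic rings is not enough to account for this grouping: compound 1 goes against that reading, for its vinyl also carries one and a 6.6-fold higher number from compound 1 to compound 4 (0.82 log units; beyond the scatter) still separates it from the acetyl compound.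

Nothing shown here gives a measured reason for these steps. The compounds shown leave open whether an amine, a carboxylic acid or a longer chain on the same saturated chain carbon would fall with ethoxy or with acetyl and cyano in this assay and whether this grouping would hold on other adenosine receptors.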